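A few compounds are considered here, and "the series" means these few. Any claim that something is new, unique, unknown or untested is made for them only; others in the source may bear on it.

Measured so far:
compound 1 `Nc1nc(O)c2c(n1)n(C1OC(CO)[C@@H](O)[C@H]1O)c(=O)n2C/C=C/c1ccccc1` gives 103 uM
compound 2 `CCCn1c(=O)n(C2OC(COP(=O)(O)O)[C@@H](O)[C@H]2O)c2nc(N)nc(O)c21` gives 15 uM
compound 3 `C=CCn1c(=O)n([C@H]2CO[C@@H](CO)C2)c2nc(N)nc(O)c21` gives 83 uM

In a functional assay (B cells) with Mus musculus as the target (a lower number here means that less compound is needed, a higher number that more compound is needed for the effect), compound 1, at 103 uM in the list above its peers, stands level with compound 3 within the scatter, while compound 2 needs clearly less compound. Compound 4 `COc1ccc(Cn2c(=O)n(C3OC(CO)[C@@H](O)[C@H]3O)c3nc(N)nc(O)c32)cc1` keeps the core of compound 1 and puts 4-methoxyphenyl in place of 2-phenylethenyl on a saturated chain carbon bound to an aromatic nitrogen. For the measured compounds named here, no measured pair differs in one place alone, so the data offer no direct guide to this swap. The expected size of the change in this assay is a 1.5-fold lower number from compound 1 to compound 4 (0.17 log units; within the scatter) and so nothing beyond the scatter. For compound 4 the estimated value is 70 uM with an expected range from 25 uM to 200 uM as its ends.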

Compound 4, concentration for half-maximal effect: 135 uM
Beside the measured number, compound 4's estimate is 1.9-fold (0.29 log units) below it; the range from low to high includes it.
By their numbers in this assay, from the lowest: compound 2; then compounds 3, 1 and 4 (each within the scatter of the next).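

In this assay, for the compounds shown here, 4-methoxyphenyl in place of 2-phenylethenyl on a saturated chain carbon bound to an aromatic nitrogen gives a 1.3-fold higher number from compound 1 to compound 4 (0.12 log units; within the scatter), the only step here that changes one place alone. At this position, then, the two groups stand level, even though one brings a hydrogen-bond acceptor and loses the double bond outside the ring. No supporting data explain this result.

Still open, from the compounds shown here alone, is how an amine or a carboxylic acid on the phenyl ring would read in this assay. Going by these compounds, a longer chain between the ring and the aromatic nitrogen is equally open.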